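Aryl exchange on the shared core: compound 2 to compound 3

This account rests on a few compounds, and the source may have more. Where it says the series, first, only, none or still open, it means among the compounds named here.

Among the compounds with values here, in a functional assay on MCF7 cells (Homo sapiens) for cytotoxicity, read by MTT assay, with a stated time of 96 h (a higher number here means a weaker inhibitor, a lower number a stronger inhibitor), compound 2 `COc1ccc(-c2cn(-c3ccccc3)cc2C(=O)c2cc(OC)c(OC)c(OC)c2)cc1` gives 70 nM as the lower of the two numbers so far, against compound 1 `COc1cc(C(=O)c2cn(-c3ccccc3)cc2-c2ccccc2Br)cc(OC)c1OC` at 190 nM on the higher side. Compound 3 `COc1cc(C(=O)c2cn(-c3ccccc3)cc2-c2c(F)cc(F)cc2F)cc(OC)c1OC` carries 2,4,6-trifluorophenyl in place of 4-methoxyphenyl on an aromatic carbon at the same place. Within the data shown here, one measured step bears on this place: a 2.7-fold lower number from compound 1 to compound 2 (0.43 log units; beyond the scatter) on exchanging 2-bromophenyl for 4-methoxyphenyl, modest and beyond the scatter. Compound 1, also halogen-bearing here, stands at 190 nM and so a modest rise is expected. An estimated 2.1-fold higher number from compound 2 to compound 3 (0.33 log units; beyond the scatter) is expected in this assay on that basis. Compound 3 is estimated at 150 nM (range 40 nM to 600 nM).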

Compound 3, half-maximal inhibitory concentration: 180 nM
Estimate against measurement, compound 3: 1.2-fold (0.08 log units) below; the measured number falls inside the stated range.
By their numbers in this assay, from the lowest: compound 2; then compounds 3 and 1 (each within the scatter of the next).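

In this assay, the two halogen-bearing aryl groups at this place cannot be told apart: 2,4,6-trifluorophenyl for 2-bromophenyl gives a 1.1-fold lower number from compound 1 to compound 3 (0.02 log units; within the scatter) and stays within the scatter. The step of a 2.6-fold higher number from compound 2 to compound 3 (0.41 log units; beyond the scatter) on replacing 4-methoxyphenyl matches in size the earlier step that brought in 4-methoxyphenyl in place of 2-bromophenyl, so 4-methoxyphenyl alone gives the lower number among the three. On these data alone, whether an unsubstituted phenyl, a 4-aminophenyl or a pyridine ring at this place would sit with compound 2 or with the halogen-bearing pair remains open. No measurement shown here explains this order.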